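Ring amine substituent variation: expected value for compound 3

A few compounds are considered here, and "the series" means these few. Any claim that something is new, unique, unknown or untested is made for them only; others in the source may bear on it.

Measured so far:
compound 1 `Nc1ccccc1NC(=O)c1ccc(CSC(=S)N2CCN(c3ccc(Cl)cc3)CC2)cc1`: 15%
compound 2 `Nc1ccccc1NC(=O)c1ccc(CSC(=S)N2CCN(Cc3ccncc3)CC2)cc1`: 18.4%
compound 3 `Cc1ccc(N2CCN(C(=S)SCc3ccc(C(=O)Nc4ccccc4N)cc3)CC2)cc1`: not yet measured

In a functional assay on MGC-803 cells (Homo sapiens) for antiproliferative activity, read by CCK-8 assay, with a stated time of 72 h, tested at 2 uM (a lower number here means a weaker effect, a higher number a stronger effect of the compound at the concentration tested), compound 1 gives 15% and compound 2 gives 18.4%. Compound 2 holds the higher of the two numbers, but the step of a number 3.4 percentage points higher from compound 1 to compound 2 (within the scatter) is within the scatter, so the two compounds cannot be ordered. Compound 3 differs from compound 2 by 4-methylphenyl in place of (pyridin-4-yl)methyl on an amine nitrogen in a ring. Within the data shown here, the only measured step that bears on this place is a number 3.4 percentage points higher from compound 1 to compound 2 (within the scatter), which also exchanged the group on the same ring nitrogen and stayed within the scatter. The group entering in compound 3 is, like that of compound 1, a six-membered aromatic ring of carbon only, so no change beyond the scatter is expected in this assay. Compound 3 is therefore estimated at about 16%, within 7% to 26%. That estimate means a step of a number 2.4 percentage points lower from compound 2 to compound 3 (within the scatter), expected to lie within the scatter.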

Compound 3, a percentage reported as inhibition, at one concentration (the size of the read-out at that concentration, not a potency): 33.4%
Estimate against measurement, compound 3: 17.4 percentage points below; the measured number lies above the stated range.
By their numbers in this assay, from the lowest: compounds 1 and 2 (each within the scatter of the next); then compound 3.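

In this assay, the group on the ring nitrogen now moves the number beyond the scatter, with a number 15 percentage points higher from compound 2 to compound 3 (beyond the scatter) for 4-methylphenyl in place of (pyridin-4-yl)methyl. A six-membered aromatic ring of carbon only does not settle the number by itself: a number 18.4 percentage points higher from compound 1 to compound 3 (beyond the scatter) for methyl in place of chloro on an aromatic carbon, so the substituent on that ring also counts in this series. Nothing at hand gives a reason for either step.

Open, on these data alone, is whether the methyl itself carries the gain, which a plain phenyl group or a methoxy or ethyl group in its place would test. Also open is whether the order of these compounds holds at other concentrations, since each number is a single-concentration read-out and not a potency.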